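The source may report more compounds than this note shows. Statements on the series, on what has been measured and on what is new or still open speak of the compounds shown alone.

Measured compounds and their numbers in an assay on cells for inhibition of Rho-associated protein kinase 2 (Homo sapiens); on this read-out lower numbers stand for stronger inhibition and higher numbers for weaker inhibition:

Compound 1 `COc1cc(-c2cn[nH]c2)c(F)cc1NC(=O)C1COc2ccccc2C1` gives 6 nM.
Compound 2 `COc1cc(NC(=O)C2COc3ccccc3C2)c(F)cc1-c1cn[nH]c1` gives 8 nM.
Compound 3 `Cc1ccc2c(c1)CC(C(=O)Nc1ccc(-c3cn[nH]c3)cc1)CO2` gives 4000 nM.

Compound 3 stands at the highest of the three numbers, and both steps from it to the others are beyond the scatter; compound 2 is nearest to it and compound 1 furthest. Compound 1 and compound 2 differ from compound 3 in the aryl ring bearing the anilide nitrogen and in the substituent on the fused ring system; their two values lie within the scatter of each other.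

The unmeasured compound 4 `CN(C)C(=O)c1ccc2c(c1)CC(C(=O)Nc1ccc(-c3cn[nH]c3)cc1)CO2` keeps the anilide and pyrazole of compound 3 and changes only the fused ring system: dimethylcarbamoyl in place of methyl on an aromatic carbon. Among the measured compounds shown here, no step between two measured compounds covers this change, so nothing here tells in which direction it should go.

For the measured compounds named here, with no matching precedent, compound 4 is expected to stay near compound 3, with a step of a 1.3-fold lower number from compound 3 to compound 4 (0.12 log units; within the scatter) that is not expected to exceed the scatter by much. For compound 4 the estimate in this assay is 3000 nM, with a range from 1000 nM to 10000 nM.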

Compound 4, half-maximal inhibitory concentration: 500 nM
Compound 4: middle estimate off by 6.0-fold (0.78 log units), on the high side, and the stated range ends above it.
By their numbers in this assay, from the lowest: compounds 1 and 2 (each within the scatter of the next); then compound 4; then compound 3.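

In this assay the aromatic carbon on the fused system, meta to a fused ring and para to a fused ring, proves sensitive to its substituent: dimethylcarbamoyl in place of methyl gives an 8.0-fold lower number from compound 3 to compound 4 (0.90 log units; beyond the scatter) with the anilide and pyrazole unchanged. Compound 3 alone could not show this, as it left open whether anything larger than methyl would be accepted at this carbon; the exchange adds heavy atoms and a hydrogen-bond acceptor, and the number falls rather than rises, though this rests on a single pair. No measurement at hand bears on what lies behind the step.

From the compounds shown here alone, it remains open whether the carbonyl or the two methyl groups on the nitrogen account for the step, which a primary amide, a methyl ketone or a carboxylic acid at the same carbon would help to separate. Also open, going by these compounds, is whether a plain hydrogen at this carbon would give a number closer to that of compound 3 or of compound 4, and whether a longer chain on the amide nitrogen, such as a morpholine amide or an aminoethyl amide, would extend the step.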